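The compounds below may be only part of what the source reports. "The series", "measured", "known", "first", "only" and "open" are said of these compounds alone.

Compound 1 `COc1cc(N2CCC(N)CC2)ccc1-c1nc2c(C)nn(C3CCN(C)CC3)c(=O)c2[nH]1` gives 7% in an assay on isolated protein for inhibition of high affinity 3',5'-cyclic-AMP phosphodiesterase 7A (Homo sapiens), read by radiometric assay and cAMP accumulation, tested at 1 uM (on this read-out higher numbers stand for more inhibition at the one concentration tested (going by the name of the read-out) and lower numbers for less inhibition), and compound 2 `CCCCC(CC)Cn1nc(C)c2nc(-c3ccc(N4CCC(N)CC4)cc3OC)[nH]c2c1=O` gives 6% in the same assay; the two numbers lie within the scatter of each other, the step being a number 1 percentage points lower from compound 1 to compound 2 (within the scatter). Compound 3 `COc1cc(N2CCC(N)CC2)ccc1-c1nc2c(C)nn(Cc3ccccc3)c(=O)c2[nH]1` differs from compound 2 by phenyl in place of 1-ethylpentyl on a saturated chain carbon bound to an aromatic nitrogen. Within the data shown here, the only measured step, the exchange on the aromatic nitrogen between compound 1 and compound 2, touched the same position and stayed within the scatter, so no step beyond the scatter is expected from compound 2 to compound 3, no change at the digits printed from compound 2 to compound 3 (within the scatter). Compound 3 is therefore estimated at 6%, in a range from -5% to 18%.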

Compound 3, a percentage reported as inhibition, at one concentration (the size of the read-out at that concentration, not a potency): 13%
Beside the measured number, compound 3's estimate is 7 percentage points below it; the range from low to high includes it.
By their numbers in this assay, from the lowest: compounds 2, 1 and 3 (each within the scatter of the next).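

Exchanging the group on the aromatic nitrogen for benzyl gives a number 7 percentage points higher from compound 2 to compound 3 (within the scatter) and a number 6 percentage points higher from compound 1 to compound 3 (within the scatter) in this assay. At this position, then, 2-ethylhexyl, 1-methylpiperidin-4-yl and benzyl, which adds an aromatic ring of carbon only, all read alike within the scatter. No evidence is available that bears on this result. The compounds shown leave open whether a carboxylic acid or an amine on the benzyl ring would move the number beyond the scatter. They also leave open whether any change elsewhere on the shared core would do so.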